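Swapping the nitrogen substituent on a benzimidazole-type core

The source may hold more compounds than are shown below. What is called first, only, known or untested is meant among the compounds shown, and "the series" means these compounds.

Going by the values given here, compound 2 `CC(C)c1onc(-c2c(Cl)cccc2Cl)c1COc1ccc(-c2nc3ccc(C(=O)O)cc3n2C2CCCCCC2)cc1` has the higher of the two numbers so far in an assay on HEK-293T cells for antagonist activity at vitamin D3 receptor (Homo sapiens), read by a luciferase reporter, with a stated time of 24 h; a lower number here means a stronger inhibitor, a higher number a weaker inhibitor: compound 2 gives 921 nM, while compound 1 `CC(C)c1onc(-c2c(Cl)cccc2Cl)c1COc1ccc(-c2nc3ccc(C(=O)O)cc3n2CC(C)(C)C)cc1` gives 861 nM. Among the compounds with values here, the one step measured at the same place, a 1.1-fold higher number from compound 1 to compound 2 (0.03 log units; within the scatter), stayed within the scatter. Compound 3 `CC(=O)C1CCC(Cn2c(-c3ccc(OCc4c(-c5c(Cl)cccc5Cl)noc4C(C)C)cc3)nc3ccc(C(=O)O)cc32)CC1` differs from compound 2 by (4-acetylcyclohexyl)methyl in place of cycloheptyl on an aromatic nitrogen. Since the earlier exchange at this aromatic nitrogen hardly moved this assay, no step beyond the scatter is expected, though the entering group is a bigger change than before. The expected step is a 1.0-fold lower number from compound 2 to compound 3 (0.01 log units; within the scatter), so compound 3 is estimated at 900 nM, between 350 nM and 2500 nM.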

Compound 3, half-maximal inhibitory concentration: > 10000 nM
Compound 3 was reported as a limit; the forecaster's own chance of this, stated with the estimate: 5%; middle value at least 11-fold (1.04 log units) away from the limit.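

Compound 3 is reported only as a limit: the limit of > 10000 nM in this assay, at which 1 of the 3 values shown sits. Even so, this aromatic nitrogen now proves sensitive to its substituent, which compound 1 and compound 2 could not show: this assay records an at least 10-fold higher number from compound 2 to compound 3 (1.03 log units; beyond the scatter) and an at least 11-fold higher number from compound 1 to compound 3 (1.06 log units; beyond the scatter). Neopentyl and cycloheptyl give matching results here, but (4-acetylcyclohexyl)methyl gives a much weaker inhibitor.

Which part of the entering group matters stays open: the acetyl, the six-membered ring or the link to the nitrogen. A plain cyclohexylmethyl group, without the acetyl, would begin to separate these.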